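The compounds below may be only part of what the source reports. "The series", "measured", "known", "first", "only" and "open" are said of these compounds alone.

Measured so far in an ADME assay on PBMC cells (Homo sapiens) for cytotoxicity; a higher number here means that more compound is tolerated, a lower number that less compound is tolerated:
compound 1 `CC(CCNC(=O)c1c(Cl)cncc1Cl)N1CCC(C(Oc2ccccn2)c2ccc(Br)cc2)CC1`: 33700 nM
compound 2 `CC(CCNC(=O)c1c(Cl)cncc1Cl)N1CCC(C(Oc2ccccn2)c2ccc(C(F)(F)F)cc2)CC1`: 34100 nM
compound 3 `CC(CCNC(=O)c1c(Cl)cncc1Cl)N1CCC(C2(c3ccc(C(F)(F)F)cc3)Cc3ccccc3O2)CC1`: 33800 nM

Among the compounds with values here, compound 2 stands at 34100 nM in this assay, and the other two numbers do not separate from it: compound 1 gives 33700 nM, and the only single-point step in the set, a 1.0-fold higher number from compound 1 to compound 2 (0.01 log units; within the scatter), lies within the scatter. Within the data shown here, compound 3 gives 33800 nM; it differs from compound 2 in more than one place, so no step is counted, and its value sits essentially on top of that of compound 2. The three numbers in this assay are therefore flat.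

Compound 4 `CC(CCNC(=O)c1c(Cl)cncc1Cl)N1CCC(C(Oc2ccccc2Cl)c2ccc(C(F)(F)F)cc2)CC1` is not yet measured in this assay. It differs from compound 2 as follows: 2-chlorophenyl in place of pyridin-2-yl on an oxygen on a saturated carbon. Among the measured compounds shown here, no measured step touches this position; the one measured step concerns a substituent on the other aromatic ring and was within the scatter. With nothing in the series pointing to a change beyond the scatter, compound 4 is expected to stay near compound 2, an expected step of a 1.1-fold lower number from compound 2 to compound 4 (0.03 log units; within the scatter). The estimate for compound 4 in this assay is 32000 nM, with a range from 15000 nM to 65000 nM.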

Compound 4, half-maximal cytotoxic concentration: 4400 nM
For compound 4 the middle estimate is 7.3-fold (0.86 log units) above the measured one, outside the stated range (below it).
By their numbers in this assay, from the lowest: compound 4; then compounds 1, 3 and 2 (each within the scatter of the next).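

In this assay, within the data shown here, the group on the oxygen on a saturated carbon is the first place where a single change moves the number beyond the scatter: 2-chlorophenyl in place of pyridin-2-yl gives a 7.8-fold lower number from compound 2 to compound 4 (0.89 log units; beyond the scatter), whereas the bromo to trifluoromethyl exchange gave a 1.0-fold higher number from compound 1 to compound 2 (0.01 log units; within the scatter). Among these compounds, the flat picture from the earlier compounds therefore does not extend to this position, where the change removes the ring nitrogen, the one hydrogen-bond acceptor counted for the leaving group, and brings in a chlorine. Nothing measured on these compounds accounts for the step.

The compounds shown leave open whether the step goes with the added chlorine, with the lost ring nitrogen, or with both, and an unsubstituted phenyl on the same oxygen would separate these readings. Also open, as far as these compounds go, are whether a chlorinated pyridin-2-yl or a phenyl bearing an amine or a carboxylic acid would give a number nearer to that of compound 2, and whether the same exchange gives a similar step with bromo in place of trifluoromethyl.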